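This account rests on a few compounds, and the source may have more. Where it says the series, first, only, none or still open, it means among the compounds named here.

In a physicochemical assay for solubility, read by HPLC, in phosphate buffer, measured as kinetic solubility, at pH 7.4 (on this read-out higher numbers stand for higher solubility and lower numbers for lower solubility), three compounds have been measured. Compound 1, with the structure `CCC(=O)c1cc(-c2ccc(F)cc2)n(-c2ccc(S(N)(=O)=O)cc2)c1C`, gives 29300 nM. Compound 2, with the structure `Cc1ccc(-c2cc(C(=O)O)c(C)n2-c2ccc(S(N)(=O)=O)cc2)cc1`, gives 10000 nM. Compound 3, with the structure `CC(C)(C)C(=O)c1cc(-c2ccc(S(N)(=O)=O)cc2)n(-c2ccc(Cl)cc2)n1`, gives 6600 nM. Among these, compound 3 stands clearly below compound 1, while compound 3 and compound 2 lie within the usual scatter of each other, so no order between those two can be read from the numbers.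

Compound 4, with the structure `CN(C(=O)c1cc(-c2ccc(S(N)(=O)=O)cc2)n(-c2ccc(Cl)cc2)n1)C1CC(F)(F)C1`, has not been measured. It differs from compound 3 in one place: (3,3-difluorocyclobutyl)(methyl)amino in place of tert-butyl on a carbonyl carbon. The group that leaves has no ring and the group that enters brings one four-membered non-aromatic ring of carbon only together with two fluorine atoms; neither group counts any hydrogen-bond donors or acceptors.

Without a measured step of this kind to rest on, the expected step from compound 3 to compound 4 is a 1.4-fold higher number from compound 3 to compound 4 (0.13 log units; within the scatter), which is not expected to reach beyond the usual scatter. Compound 4 is therefore estimated at 9000 nM, with a range from 3000 nM to 27000 nM.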

Compound 4, solubility: 30900 nM
For compound 4 the middle estimate is 3.4-fold (0.54 log units) below the measured one, and the stated range ends below it.
By their numbers in this assay, from the lowest: compounds 3 and 2 (each within the scatter of the next); then compounds 1 and 4 (each within the scatter of the next).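

In this assay, among these compounds, putting (3,3-difluorocyclobutyl)(methyl)amino in place of tert-butyl on a carbonyl carbon gives a 4.7-fold higher number from compound 3 to compound 4 (0.67 log units; beyond the scatter), the first step here that can be read at a single place. This shows that the number depends on what this carbonyl carbon carries. Here, a group with more heavy atoms and a four-membered ring came with a higher number, not a lower one, though nothing measured here bears on why. One pair cannot separate the contributions of the nitrogen, the ring and the two fluorine atoms. Going by these compounds, how a dimethylamino group or a cyclobutyl(methyl)amino group without fluorine would read on the same carbonyl carbon stays open, and so does whether this step would carry over to another core.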